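This account rests on a few compounds, and the source may have more. Where it says the series, first, only, none or still open, it means among the compounds named here.

Measured so far in an in vitro ADME assay on microsomes (Rattus norvegicus) for metabolic stability; on this read-out lower numbers stand for a shorter-lived compound and higher numbers for a longer-lived compound:
- compound 1 `CCC(CC)Nc1nc(C)c(-c2ccc(Cl)cc2Cl)nc1C`: 0.0533 h
- compound 2 `CCc1nc(N(CC2CC2)CC2CC2)c(CC)nc1-c1ccc(Cl)cc1Cl`: < 0.0167 h (a limit, not a number)
- compound 3 `CCc1nc(-c2ccc(OC(F)F)cc2Cl)c(OC)nc1NC(CC)CC`: 0.283 h

Compound 2 has no numerical value and sits at the limit of < 0.0167 h in this assay, at which 1 of the 3 values shown sits. Its true position in this assay is therefore known only as a limit.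

The step under review leads to compound 4 `CCc1nc(-c2ccc(Cl)cc2Cl)c(CC)nc1NC(CC)CC`. Here (pentan-3-yl)amino takes the place of bis(cyclopropylmethyl)amino on an aromatic carbon, para to a 2,4-dichlorophenyl group ((pentan-3-yl)amino in place of bis(cyclopropylmethyl)amino on an aromatic carbon).

Among the compounds with values here, no step between measured compounds isolates this change, so the expectation rests on indirect evidence. The entering (pentan-3-yl)amino is also carried by compound 1, which gives 0.0533 h, and by compound 3, which gives 0.283 h. Both of these are numbers, and compound 1 also shares the 2,4-dichlorophenyl group with compound 4, so it serves as the main guide. A modest rise in this assay is expected, toward a longer-lived compound, and it may only just clear the usual scatter. The expected size of the change is an at least 2.3-fold higher number from compound 2 to compound 4 (0.37 log units; beyond the scatter). For compound 4 the estimated half-life is 0.04 h, with an expected range from 0.018 h to 0.1 h.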

Compound 4, half-life: 0.07 h
Estimate against measurement, compound 4: 1.8-fold (0.24 log units) below; low and high end bracket the measured number.
By their numbers in this assay, from the lowest: compounds 1 and 4 (each within the scatter of the next); then compound 3. At a limit, below all of these: compound 2.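

In this assay the exchange of bis(cyclopropylmethyl)amino for (pentan-3-yl)amino on the aromatic carbon para to a 2,4-dichlorophenyl group gives an at least 4.1-fold higher number from compound 2 to compound 4 (0.62 log units; beyond the scatter). This is the first pair shown that differs in one place, so the effect of this exchange can now be read on an otherwise unchanged core, where before the two amino groups stood only on compounds that also differed elsewhere. The printed size is a lower bound and the true gap may be larger, because compound 2 carries a limit and not a number: the limit of < 0.0167 h in this assay, at which 1 of the 4 values shown sits.

The exchange removes the two three-membered rings, shortens the substituent and adds a hydrogen-bond donor all at once, and the compounds shown do not tell which of these differences goes with the longer half-life. A cyclopropylmethylamino group at this position, or (pentan-3-yl)amino with a methyl on its nitrogen, would begin to separate them.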